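Removing the 4-Chlorobenzyl Group: An Expected Loss of Potency

This account rests on a few compounds, and the source may have more. Where it says the series, first, only, none or still open, it means among the compounds named here.

Compound 1 `CN(C)Cc1ccc2nc(NC(=O)N/N=C/c3c[nH]c4ccccc34)sc2c1`: 2550 nM
Compound 2 `CCN(CC)Cc1ccc2nc(NC(=O)N/N=C/c3cn(Cc4ccc(Cl)cc4)c4ccccc34)sc2c1`: 370 nM
Compound 3 `CN(C)Cc1ccc2nc(NC(=O)N/N=C/c3cn(Cc4ccc(Cl)cc4)c4ccccc34)sc2c1`: 290 nM

These three compounds were all tested in a functional assay on NCI-H460 cells (Homo sapiens) for cytotoxicity, read by MTT assay, with a stated time of 72 h; a lower number here means a stronger inhibitor, a higher number a weaker inhibitor. Compound 4 `CCN(CC)Cc1ccc2nc(NC(=O)N/N=C/c3c[nH]c4ccccc34)sc2c1` has not yet been measured. It arises from compound 2 by a single change, (hydrogen in place of 4-chlorobenzyl on an aromatic nitrogen). That same change has already been made once among the measured compounds, from compound 3 to compound 1: hydrogen in place of 4-chlorobenzyl on an aromatic nitrogen. Its effect there was an 8.8-fold higher number from compound 3 to compound 1 (0.94 log units; beyond the scatter), a clear weakening.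

The two starting points, compound 2 and compound 3, differ only in their cores: diethylamino in place of dimethylamino on a saturated chain carbon bound to an aromatic carbon. That difference hardly moves the read-out, as a 1.3-fold lower number from compound 2 to compound 3 (0.11 log units; within the scatter) shows. The place of the change is the same in both pairs, word for word, so the earlier step is the best guide.

For compound 4 the expected step is an 8.6-fold higher number from compound 2 to compound 4 (0.94 log units; beyond the scatter), which rests on an 8.8-fold higher number from compound 3 to compound 1 (0.94 log units; beyond the scatter) and on the near-identical behaviour of compound 2 and compound 3. Compound 4 is therefore estimated at 3200 nM, with a likely range from 1200 nM to 8000 nM.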

Compound 4, half-maximal inhibitory concentration: 3140 nM
For compound 4 the middle estimate is 1.0-fold (0.01 log units) above the measured one, within the range that was stated.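

In this assay, removing the 4-chlorobenzyl group gives an 8.5-fold higher number from compound 2 to compound 4 (0.93 log units; beyond the scatter), and this loss of potency closely matches the one seen on the other core: the same change on two cores in this assay, an 8.8-fold higher number (0.94 log units; beyond the scatter) from compound 3 to compound 1 and an 8.5-fold higher number (0.93 log units; beyond the scatter) from compound 2 to compound 4, 1.0-fold (0.02 log units) apart, within the scatter of two such steps

Exchanging dimethylamino for diethylamino, seen here as a 1.2-fold higher number from compound 1 to compound 4 (0.09 log units; within the scatter), also behaves alike with and without the 4-chlorobenzyl group: the same change on two cores in this assay, a 1.3-fold lower number (0.11 log units; within the scatter) from compound 2 to compound 3 and a 1.2-fold lower number (0.09 log units; within the scatter) from compound 4 to compound 1, 1.0-fold (0.02 log units) apart, within the scatter of two such steps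

Together, these results show that the two changes add up independently across these four compounds, but only for these two amines in this one assay, so they do not show why the 4-chlorobenzyl group matters or whether its effect would carry over to a core altered elsewhere.

The compounds shown leave open how much of the step belongs to the chlorine and how much to the benzyl group, a question that a plain benzyl or a methyl group on the same aromatic nitrogen could help settle. They also leave open whether the step would stay the same with a ring amine such as morpholine in place of diethylamino.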